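The compounds below may be only part of what the source reports. "The series", "measured", "known", "first", "only" and "open" are said of these compounds alone.

Values in a functional assay on HCT-116 cells (Homo sapiens) for cytotoxicity, read by MTT assay, with a stated time of 72 h (on this read-out lower numbers stand for stronger inhibition and higher numbers for weaker inhibition), stand as follows

Compound 1 `COc1cc(/C=C/c2cc(C)[nH]n2)ccc1O` gives 78800 nM
Compound 2 `Cc1cc(/C=C/c2ccc(O)c(O)c2)on1` gives 5300 nM
Compound 3 `COc1ccc(/C=C/c2cc(C)n[nH]2)cc1OC` gives 51300 nM

Compound 2 holds the lowest number of the three, and the gaps up to compound 3 and compound 1 both lie beyond the scatter. For the measured compounds named here, those two differ from compound 2 in more than one place, so no single-change step is available. Compound 4 `Cc1cc(/C=C/c2ccc(O)cc2)on1` departs from compound 2 at one spot: hydrogen in place of hydroxy on an aromatic carbon, ortho to a hydroxy group. Compound 2 sits at the low end with 5300 nM, so weaker inhibition, beyond the scatter, is expected. The expected size is a 4.7-fold higher number from compound 2 to compound 4 (0.67 log units; beyond the scatter), an estimate only. For compound 4 the estimated value in this assay is 25000 nM, with an expected range of 9000 nM to 70000 nM.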

Compound 4, half-maximal inhibitory concentration: 67900 nM
Compound 4: the middle estimate sits 2.7-fold (0.43 log units) below what was measured; low and high end bracket the measured number.
By their numbers in this assay, from the lowest: compound 2; then compounds 3, 4 and 1 (each within the scatter of the next).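

In this assay, hydrogen in place of hydroxy, ortho to a hydroxy group, gives a 13-fold higher number from compound 2 to compound 4 (1.11 log units; beyond the scatter) as the only single-change comparison among these compounds. The earlier compounds shown here could not isolate this position, whereas this large step shows that inhibition depends on the hydroxy group there. Nothing shown explains the loss. As far as these compounds go, it remains open whether an amine or a fluorine atom at this position would retain the inhibition of compound 2, and whether the same change would have a similar effect on the core of compound 1.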